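This account rests on a few compounds, and the source may have more. Where it says the series, first, only, none or still open, it means among the compounds named here.

Measured so far in an ADME assay on Vero cells (Chlorocebus sabaeus) for cytotoxicity, read by MTT assay, with a stated time of 72 h; on this read-out lower numbers stand for higher toxicity in this test and higher numbers for lower toxicity in this test:
Compound 1 `COC(=O)c1cc(-c2cccc(NC(=O)c3ccc(/C=C/C(=O)c4ccccc4)cc3)c2)on1`: > 50 ug/mL, a limit of the assay.
Compound 2 `COC(=O)c1cc(-c2cccc(NC(=O)c3ccc(/C=C/C(=O)c4cccs4)cc3)c2)on1`: "not determined" (no result reported).
Compound 3 `CCOc1ccc(C(=O)/C=C/c2ccc(C(=O)Nc3cccc(-c4cc(C(=O)OC)no4)c3)cc2)cc1`: > 40 ug/mL, a limit of the assay.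

Compound 1 stands only at a limit in this assay; no single number is known for it. Compound 3 likewise sits at a limit, and compound 2 gives no result at all. For the measured compounds named here, the one step, a step that the two limits leave unreadable from compound 1 to compound 3, is unreadable, with the limit of > 50 ug/mL in this assay, at which 1 of the 3 values shown sits, at one end and the limit of > 40 ug/mL in this assay, at which 1 of the 3 values shown sits, at the other. The change to compound 4 `COC(=O)c1cc(-c2cccc(NC(=O)c3ccc(/C=C/C(=O)c4ccc(Cl)cc4)cc3)c2)on1` is chloro in place of hydrogen on an aromatic carbon. Going by the values given here, no measured step speaks to this change, so no step beyond the scatter is expected in either direction. Compound 4 is expected to sit at or near the limit as well, as a step that the limit leaves unreadable from compound 1 to compound 4. The estimate for compound 4 is 60 ug/mL, within 30 ug/mL to 120 ug/mL.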

Compound 4, half-maximal cytotoxic concentration: > 50 ug/mL
Compound 4: a limit, no number; the forecaster's own chance of this, stated with the estimate: 70%; the middle value does not contradict the limit.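

In this assay compound 4 gives only a limit, as do compound 1 and compound 3, and the steps from compound 1 and compound 3 to compound 4 cannot be read. The compounds shown leave open whether chloro or ethoxy in place of hydrogen changes the half-maximal cytotoxic concentration at all.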